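The source may hold more compounds than are shown below. What is called first, only, known or untested is meant among the compounds shown, and "the series" means these compounds.

Among the compounds with values here, compound 2 `Cc1cccc(CN2CCC(CCCC(=O)c3ncco3)CC2)c1` is one of two compounds measured in an assay on isolated protein for inhibition of Fatty-acid amide hydrolase 1 (Homo sapiens); on this read-out higher numbers stand for weaker inhibition and lower numbers for stronger inhibition; compound 2 gives 90 nM. Compound 1 `O=C(CCCC1CCN(C(=O)C2CCCCC2)CC1)c1ncco1` gives 45 nM, and the step of a 2.0-fold higher number from compound 1 to compound 2 (0.30 log units; within the scatter) is within the scatter, so the two numbers cannot be told apart. Compound 3 `O=C(CCCC1CCN(Cc2cccc(Br)c2)CC1)c1ncco1` differs from compound 2 by bromo in place of methyl on an aromatic carbon. Within the data shown here, no measured step involves bromo in place of methyl on an aromatic carbon, so nothing in the data speaks for a shift in either direction; the change is expected to bring a 1.3-fold lower number from compound 2 to compound 3 (0.11 log units; within the scatter), nothing beyond the scatter. Compound 3 is therefore estimated at 70 nM, in the range 25 nM to 200 nM.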

Compound 3, half-maximal inhibitory concentration: 10 nM
For compound 3 the middle estimate is 7.0-fold (0.85 log units) above the measured one, and the stated range ends above it.
By their numbers in this assay, from the lowest: compound 3; then compounds 1 and 2 (each within the scatter of the next).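

Bromo in place of methyl on this aromatic carbon gives a 9.0-fold lower number from compound 2 to compound 3 (0.95 log units; beyond the scatter), so a change of one heavy atom at this position can move the number beyond the scatter, something the earlier pair did not show. The 3-bromobenzyl group also separates from cyclohexylcarbonyl on the ring nitrogen, with a 4.5-fold lower number from compound 1 to compound 3 (0.65 log units; beyond the scatter), whereas 3-methylbenzyl could not be told apart from it. The data shown offer no measurement that explains this gain. On these data alone, whether chloro, iodo or trifluoromethyl at this carbon would match bromo stays open, as does whether bromo on another carbon of the ring would keep the gain.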